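The compounds below may be only part of what the source reports. "The series", "measured", "known", "first", "only" and "open" are said of these compounds alone.

Compound 1 `CC(=O)Nc1nc2ccc(NC(=O)c3c(Cl)cccc3Cl)cc2s1`: 0.6 ug/mL
Compound 2 `O=C(Nc1ccc2nc(NCC3CCCCC3)sc2c1)c1c(Cl)cccc1Cl`: 4.3 ug/mL

Within the data shown here, in a functional assay on WI-38 VA13 cells (Homo sapiens) for cytotoxicity (on this read-out higher numbers stand for an effect only at larger amounts of compound and lower numbers for an effect already at smaller amounts), compound 2 gives the higher of the two numbers measured so far; the only neighbour it has is compound 1, and the step of a 7.2-fold higher number from compound 1 to compound 2 (0.86 log units; beyond the scatter) places compound 2 well apart from it. Compound 3 `COc1ccccc1Nc1nc2ccc(NC(=O)c3c(Cl)cccc3Cl)cc2s1` is reached from compound 2 by a single change: 2-methoxyphenyl in place of cyclohexylmethyl on a nitrogen on an aromatic ring. Among the measured compounds shown here, the one measured step that touches this nitrogen, a 7.2-fold higher number from compound 1 to compound 2 (0.86 log units; beyond the scatter), exchanged acetyl for cyclohexylmethyl and moved the number by a modest amount. For the measured compounds named here, no measured pair shows an aromatic substituent at this position, so the direction of the next step cannot be read from the data. The expectation for compound 3 is therefore a step of a 1.4-fold lower number from compound 2 to compound 3 (0.16 log units; within the scatter) that stays within the scatter, with wide uncertainty on either side. Compound 3 is estimated at 3 ug/mL in this assay, within a range from 0.7 ug/mL to 13 ug/mL.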

Compound 3, half-maximal effective concentration: > 7.2 ug/mL
Compound 3 was reported as a limit; the forecaster's own chance of this, stated with the estimate: 5%; middle value at least 2.4-fold (0.38 log units) from the limit.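

For compound 3 the reading in this assay is a limit and not a number: the limit of > 7.2 ug/mL in this assay, at which 1 of the 3 values shown sits.

Set against acetyl, the aromatic 2-methoxyphenyl group on this nitrogen gives an at least 12-fold higher number from compound 1 to compound 3 (1.07 log units; beyond the scatter), the same direction as a 7.2-fold higher number from compound 1 to compound 2 (0.86 log units; beyond the scatter), so among these three compounds the lowest number goes with acetyl. Set against cyclohexylmethyl, the same group gives an at least 1.6-fold higher number from compound 2 to compound 3 (0.22 log units; that floor lies within the scatter); that floor lies within the scatter, so the limit does not separate compound 3 from compound 2, although the true gap may be wider.

The compounds shown leave open how much of this result belongs to the methoxy group and how much to the aromatic ring itself, which a plain phenyl group could separate. Going by these compounds, what an amine or a carboxylic acid on a longer chain would do at this nitrogen also remains open.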